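A few compounds are considered here, and "the series" means these few. Any claim that something is new, unique, unknown or untested is made for them only; others in the source may bear on it.

This account follows the shared core of compound 1 `Cn1c(Cc2nn(C)c(=O)c3ccccc23)nnc1SCCCCCCCCCCC(=O)Nc1ccccc1Cl` through three measured compounds and on to a fourth that has not yet been tested. In an assay on isolated protein (Mus musculus) for inhibition of IL15-IL15 receptor (Homo sapiens), read by resazurin assay, with stated times of 30 min and 2.5 days (on this read-out lower numbers stand for stronger inhibition and higher numbers for weaker inhibition), compound 1 gives 15000 nM. Compound 3 `CCCOc1ccc(NC(=O)CCCCCCCSc2nnc(Cc3nn(C)c(=O)c4ccccc34)n2C)cc1` gives 1600 nM in this assay, a stronger reading than compound 1 by a margin beyond the usual scatter. Compound 2 `CC(C)Oc1ccc(NC(=O)CSc2nnc(Cc3nn(C)c(=O)c4ccccc34)n2C)cc1` is reported in this assay only as > 30000 nM, which is a limit of the assay and not a number, and (the limit of > 30000 nM in this assay, at which 1 of the 3 values shown sits). Compound 2 therefore stands at the weak end of what has been measured, with no numerical value of its own.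

Compound 4 `Cn1c(Cc2nn(C)c(=O)c3ccccc23)nnc1SCC(=O)Nc1ccc(Cl)cc1Cl` differs from compound 2 in one place: 2,4-dichlorophenyl in place of 4-isopropoxyphenyl on an amide-type nitrogen. For the measured compounds named here, no pair of measured compounds differs in exactly this way, so the size of the change cannot be read from a measured step. Since compound 2 is known only as a limit, the expected step in this assay is an at least 1.2-fold lower number from compound 2 to compound 4 (0.07 log units; that floor lies within the scatter), and it is not expected to carry compound 4 far from where compound 2 stands. Compound 4 is accordingly estimated to give 25000 nM in this assay, with a range from 8000 nM to 60000 nM.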

Compound 4, half-maximal inhibitory concentration: 17300 nM
Estimate against measurement, compound 4: 1.4-fold (0.16 log units) above, within the range that was stated.
By their numbers in this assay, from the lowest: compound 3; then compounds 1 and 4 (each within the scatter of the next). At a limit, above all of these: compound 2.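

In this assay, 2,4-dichlorophenyl in place of 4-isopropoxyphenyl on an amide-type nitrogen gives an at least 1.7-fold lower number from compound 2 to compound 4 (0.23 log units; that floor lies within the scatter). With that change, this position yields a numerical reading, as compound 4 gives 17300 nM, and nothing else in the molecule differs from compound 2. The step has only a floor, and its true size stays unknown, because compound 2 is held at a limit of the assay and not at a number: the limit of > 30000 nM in this assay, at which 1 of the 4 values shown sits.

Compounds 1 and 3 each differ from compound 4 in more than one place, so the compounds shown do not separate the contribution of the chain between the sulfur and the amide from that of the aromatic group on the amide-type nitrogen. As far as these compounds go, it remains open how this position would read with a carboxylic acid or an amine on that aromatic group, and whether 2,4-dichlorophenyl would keep or change its reading on a longer chain.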